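A Dichlorophenyl Swap and Its Expected Effect on Cytotoxicity

The compounds below may be only part of what the source reports. "The series", "measured", "known", "first", "only" and "open" are said of these compounds alone.

Measured compounds in a functional assay on U-937 cells (Homo sapiens) for cytotoxicity, read by CCK-8 assay, with a stated time of 72 h; a lower number here means a stronger inhibitor, a higher number a weaker inhibitor:
compound 1, `COc1ccccc1/C=c1/[nH]c(=O)/c(=C\c2ccccc2OC)n(C)c1=O`, gives 1500 nM
compound 2, `COc1ccccc1/C=c1/[nH]c(=O)/c(=C\c2cccc(Cl)c2Cl)[nH]c1=O`, is recorded as "not active" (no number reported), with no number reported
compound 3, `C=CCn1c(=O)/c(=C\c2ccccc2Cl)[nH]c(=O)/c1=C\c1ccccc1OC`, gives 700 nM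

Compound 3 holds the lowest of the two numbers shown, and its gap to compound 1 lies beyond the usual scatter. Compound 4, `C=CCn1c(=O)/c(=C\c2ccc(Cl)c(Cl)c2)[nH]c(=O)/c1=C\c1ccccc1OC`, has not yet been measured. It differs from compound 3 in one place: 3,4-dichlorophenyl in place of 2-chlorophenyl on a double-bonded chain carbon bound to an aromatic carbon. Within the data shown here, no measured pair shows this exact change, so its size is uncertain. Compound 2, which also carries two chlorines on one ring, gave no number, which leans toward a weakening. Compound 4 is therefore expected to be somewhat weaker than compound 3, with the step of a 2.1-fold higher number from compound 3 to compound 4 (0.33 log units; beyond the scatter) estimated as modest. The estimate for compound 4 is 1500 nM, ranging from 400 nM to 6000 nM.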

Compound 4, half-maximal inhibitory concentration: "not active" (no number reported)
Compound 4 has no reported number here, and the estimate cannot be compared.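

In this assay, among these compounds, compound 4 is recorded as "not active" with no number, so no step from compound 3 to compound 4 can be read. Nothing at hand explains this result. From the compounds shown here alone, how much activity the change from 2-chlorophenyl to 3,4-dichlorophenyl costs remains open.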